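A few compounds are considered here, and "the series" means these few. Any claim that something is new, unique, unknown or untested is made for them only; others in the source may bear on it.

Working notes on the series, read in a functional assay on MDA-MB-435 cells (Homo sapiens) for inhibition; on this read-out lower numbers stand for stronger inhibition of growth and higher numbers for weaker inhibition of growth. Compound 1 (`NS(=O)(=O)c1ccc(/C=C/c2ccc(F)cc2)cc1`) gives 27000 nM. Compound 2 (`NS(=O)(=O)c1ccc(/C=C/c2cccc(O)c2)cc1`) gives 25800 nM. For the measured compounds named here, these are the only two numbers so far. They lie within the usual scatter of each other, so compound 1 stands level with compound 2 and the pair sets no real range.

The next compound is compound 3 (`CN(C)c1ccc(/C=C/c2ccc(S(N)(=O)=O)cc2)cc1`). Relative to compound 1 it has dimethylamino in place of fluoro on an aromatic carbon, para to a large group: dimethylamino in place of fluoro on an aromatic carbon. Going by the values given here, no measured pair differs in one place only, so this exchange has no direct precedent in the data. With a different substituent, compound 2 at 25800 nM still reads level with compound 1, so only a modest step is expected in this assay, most likely towards stronger inhibition of growth, though no change beyond the scatter remains possible. The estimated step is a 1.9-fold lower number from compound 1 to compound 3 (0.29 log units; within the scatter). For compound 3 the estimated value is 14000 nM, with an expected range from 4000 nM to 40000 nM.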

Compound 3, concentration for 50% growth inhibition: 7630 nM
The estimate for compound 3 lay 1.8-fold (0.26 log units) above the measured number; the measured number falls inside the stated range.
By their numbers in this assay, from the lowest: compound 3; then compounds 2 and 1 (each within the scatter of the next).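

In this assay, for the compounds shown here, dimethylamino in place of fluoro on an aromatic carbon, para to a large group, gives a 3.5-fold lower number from compound 1 to compound 3 (0.55 log units; beyond the scatter) and is the first single-place change that can be read directly. Compounds 1 and 2 stood level and differ in more than one place, so they showed nothing specific about this position, whereas this pair shows that the group held there can move the read-out beyond the scatter, here towards stronger inhibition of growth, though the step is modest and rests on one pair. No measurement at hand accounts for the step.

From the compounds shown here alone, it stays open whether this shift is particular to dimethylamino or would also appear at this position with a primary amine, a methoxy group or a carboxylic acid. Also open, going by these compounds, is whether longer chains on the nitrogen, such as diethylamino, would extend the step, hold it or lose it, and whether the same exchange would read alike on another core.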